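Ring size at the thiocarbonyl carbon across two cores

The source may report more compounds than this note shows. Statements on the series, on what has been measured and on what is new or still open speak of the compounds shown alone.

Compound 3 `O=c1c(SC(=S)N2CCCCC2)coc2ccc(Cl)cc12` and compound 1 `O=c1c(SC(=S)N2CCCC2)coc2ccc(Cl)cc12` share one core; in a functional assay on MDA-MB-435S cells (Homo sapiens) for antiproliferative activity, read by MTT assay, with a stated time of 72 h (on this read-out lower numbers stand for stronger inhibition and higher numbers for weaker inhibition), compound 3 gives 13300 nM and compound 1 gives 24000 nM. The change between them, (pyrrolidin-1-yl in place of piperidin-1-yl on a thiocarbonyl carbon), produced a 1.8-fold higher number from compound 3 to compound 1 (0.26 log units; within the scatter). Compound 2 `O=c1c(CSC(=S)N2CCCCC2)coc2cc(Cl)ccc12` rests on a different core; how the core of compound 2 differs from that of compound 3 is not broken down here. In this assay compound 2 gives 240 nM, the lowest of the three numbers. Compound 4 `O=c1c(CSC(=S)N2CCCC2)coc2cc(Cl)ccc12` is the unmeasured partner of compound 2 and carries pyrrolidin-1-yl in place of piperidin-1-yl on a thiocarbonyl carbon, the same change at the same place as the one made in the other core. The step from compound 2 to compound 4 is expected to be about a 1.5-fold higher number from compound 2 to compound 4 (0.16 log units; within the scatter), because the same change earlier gave a 1.8-fold higher number from compound 3 to compound 1 (0.26 log units; within the scatter). Compound 4 is therefore estimated near 350 nM, most likely between 150 nM and 900 nM.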

Compound 4, half-maximal inhibitory concentration: 6400 nM
For compound 4 the middle estimate is 18-fold (1.26 log units) below the measured one; the whole stated range lies below it.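

In this assay, putting pyrrolidin-1-yl in place of piperidin-1-yl on a thiocarbonyl carbon costs far more on the core of compound 2, with a 27-fold higher number from compound 2 to compound 4 (1.43 log units; beyond the scatter). The size of this step therefore does not carry from one core to the other: the same change on two cores in this assay, a 1.8-fold higher number (0.26 log units; within the scatter) from compound 3 to compound 1 and a 27-fold higher number (1.43 log units; beyond the scatter) from compound 2 to compound 4, 15-fold (1.17 log units) apart, beyond the scatter of two such steps

Among these compounds, with only one pair on each core, this shows that the outcome of the change depends on the core, but not which feature of the core is responsible, nor any rule for further cores.

As far as these compounds go, whether morpholin-4-yl or dimethylamino on the thiocarbonyl carbon of the core of compound 2 would stay close to compound 2 or to compound 4 remains open. Also open, from the compounds shown here alone, is whether the large step recurs on cores other than these two.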